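From 2-chlorophenyl to 4-aminophenyl at the assay limit

This account rests on a few compounds, and the source may have more. Where it says the series, first, only, none or still open, it means among the compounds named here.

Of the compounds shown here, three have been measured in a functional assay on COLO 205 cells (Homo sapiens) for cytotoxicity, read by MTT assay, with a stated time of 48 h (a higher number here means a weaker inhibitor, a lower number a stronger inhibitor), so far. Compound 1 (`Fc1cccc(-c2nc(Nc3ccccc3)c3ccccc3n2)c1`) gives > 50000 nM as a limit and not a number. Compound 2 (`COc1ccccc1Nc1nc(-c2cccc(F)c2)nc2ccc(F)cc12`) gives > 50000 nM and this too is a limit. Compound 3 (`Fc1cccc(-c2nc(Nc3ccccc3Cl)c3cc(F)ccc3n2)c1`) gives > 50000 nM which is again a limit. Compound 3 therefore has no exact value and cannot be ranked against the other two. Within the data shown here, the whole record so far is the limit of > 50000 nM in this assay, at which 3 of the 3 values shown sit, and no measured compound has yet produced a number.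

Compound 4 (`Nc1ccc(Nc2nc(-c3cccc(F)c3)nc3ccc(F)cc23)cc1`) is still unmeasured. It differs from compound 3 in one place: 4-aminophenyl in place of 2-chlorophenyl on a nitrogen on an aromatic ring with 4-aminophenyl in place of 2-chlorophenyl on a nitrogen on an aromatic ring.

Among the measured compounds shown here, only one measured step bears on this position, and it is a step that the two limits leave unreadable from compound 2 to compound 3 so it offers no size to carry over. For the measured compounds named here, no measured compound carries a 4-aminophenyl group, which leaves the expectation loose, with only a slight lean towards stronger inhibition. The expected step is an at least 2.5-fold lower number from compound 3 to compound 4 (0.39 log units; beyond the scatter) in this assay and it may prove no more readable than the last one. Compound 4 is estimated at 20000 nM with an expected range from 3000 nM to 60000 nM and the assay may again report only a limit.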

Compound 4, half-maximal inhibitory concentration: > 50000 nM
Compound 4: a limit, no number (the forecaster's own chance of this, stated with the estimate: 50%); at least 2.5-fold (0.39 log units) between middle value and limit.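

Among these compounds, no step from compound 2 or compound 3 to compound 4 can be read, because compound 4 also gives a limit and not a number: the limit of > 50000 nM in this assay, at which 4 of the 4 values shown sit.

In this assay the compounds shown leave open whether any group on this nitrogen gives a measurable value, and how far each compound lies beyond the limit.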